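From quinolin-6-yl to 4-fluorophenyl on a carbonyl carbon

A few compounds are considered here, and "the series" means these few. Any claim that something is new, unique, unknown or untested is made for them only; others in the source may bear on it.

Compound 1 `COc1ccc(S(=O)(=O)Oc2ccccc2NC(=O)c2ccncc2)cc1`, with pyridin-4-yl on a carbonyl carbon, gives 89 nM in a functional assay on HCT-15 cells (Homo sapiens) for antiproliferative activity; a lower number here means a stronger inhibitor, a higher number a weaker inhibitor. Compound 2 `COc1ccc(S(=O)(=O)Oc2ccccc2NC(=O)c2ccc3ncccc3c2)cc1` gives > 10000 nM in this assay, and this is a limit of the assay, not a number. Within the data shown here, the only measured step, an at least 110-fold higher number from compound 1 to compound 2 (2.05 log units; beyond the scatter), is large and beyond the scatter, with quinolin-6-yl in place of pyridin-4-yl on a carbonyl carbon.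

Compound 3 `COc1ccc(S(=O)(=O)Oc2ccccc2NC(=O)c2ccc(F)cc2)cc1` changes the same place: 4-fluorophenyl in place of quinolin-6-yl on a carbonyl carbon. Among the measured compounds shown here, no measurement yet exists for 4-fluorophenyl on the shared core, so the single step above is the only guide. It shows that the group on this carbonyl carbon can move the read-out a long way. Removing quinolin-6-yl is expected to recover part of that loss, though not all of it, with compound 1 at 89 nM as the reference. The estimated move is an at least 12-fold lower number from compound 2 to compound 3 (1.09 log units; beyond the scatter), towards a lower number and beyond the scatter. The expected value for compound 3 is 800 nM, with an estimated range of 100 nM to 6000 nM.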

Compound 3, half-maximal inhibitory concentration: 89 nM
Estimate against measurement, compound 3: 9.0-fold (0.95 log units) above; measured number outside the range, below it.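

The step of no change at the digits printed from compound 1 to compound 3 (within the scatter) in this assay shows that a ring of carbon only, 4-fluorophenyl, serves on this carbonyl carbon as well as pyridin-4-yl, so a nitrogen in this ring is not required for the read-out in this pair. The reverse move, an at least 110-fold lower number from compound 2 to compound 3 (2.05 log units; beyond the scatter), shows that the loss seen with quinolin-6-yl is regained in full rather than in part, which ties that loss to quinolin-6-yl itself and not to the position as a whole, and the two single-ring groups stand together against the one two-ring group among these three compounds. The true size of this step remains unknown, as compound 2 is held only by a limit of the assay, not a number: the limit of > 10000 nM in this assay, at which 1 of the 3 values shown sits.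

Still open, from the compounds shown here alone, is whether the second ring of quinolin-6-yl or the placement of its nitrogen accounts for the loss, a question that naphthalen-2-yl, a two-ring group of carbon only, would address. Also open, going by these compounds, is how far this position tolerates other groups, such as unsubstituted phenyl, a saturated amine like piperidin-4-yl, or a phenyl ring bearing a carboxylic acid.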